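The source may report more compounds than this note shows. Statements on the series, on what has been measured and on what is new or still open speak of the compounds shown alone.

Measured so far: compound 1 `CCC(C)C1NC(=O)N(C2CCCCC2)C1=O` with > 100000 nM; compound 2 `CCC(C)C1NC(=O)N(C2CCCC2)C1=O` with > 100000 nM; compound 3 `CC(C)C1NC(=O)N(C2CCCC2)C1=O` with > 100000 nM.

In a functional assay on MIA PaCa-2 cells (Homo sapiens) for inhibition (a lower number here means a stronger inhibitor, a higher number a weaker inhibitor), compound 1 gives only a limit, > 100000 nM. Compound 2 likewise reaches only a limit, > 100000 nM. Compound 3 too stops at a limit, > 100000 nM. All three therefore sit at the limit of > 100000 nM in this assay, at which 3 of the 3 values shown sit.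

Compound 3 differs from compound 2 by hydrogen in place of methyl on a saturated chain carbon, two bonds along the chain from a saturated ring carbon. The step that the two limits leave unreadable from compound 2 to compound 3 cannot be read, since both ends are limits. The difference between the cores of compound 1 and compound 2 is not broken down here.

Compound 4 `CC(C)C1NC(=O)N(C2CCCCC2)C1=O`, not yet measured, differs from compound 1 by hydrogen in place of methyl on a saturated chain carbon, two bonds along the chain from a saturated ring carbon, the same kind of change as that from compound 2 to compound 3. Because compound 1 sits at > 100000 nM and the earlier step gave no readable size, compound 4 is expected to stay at the limit as well, with an estimated step that the limit leaves unreadable from compound 1 to compound 4. The estimate for compound 4 is 200000 nM, between 100000 nM and 1000000 nM.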

Compound 4, half-maximal inhibitory concentration: > 100000 nM
Compound 4 was reported as a limit (the forecaster's own chance of this, stated with the estimate: 90%); the middle value is on the limit's open side.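

Compound 1 and compound 4 both stop at a limit in this assay, so no step between them can be read: the limit of > 100000 nM in this assay, at which 4 of the 4 values shown sit.

The compounds shown leave open whether changing sec-butyl to isopropyl affects inhibition at all.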